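This account rests on a few compounds, and the source may have more. Where it says the series, first, only, none or still open, it means among the compounds named here.

Compound 1 `C=CC(=O)N1CC[C@H](N2C(=O)N(c3ccccc3)Cc3cnc(Nc4ccc(N5CCN(C)CC5)cc4)nc32)C1` serves as the reference point. In an ADME assay on the whole organism (strain Sprague-Dawley) for pharmacokinetics, with Rattus norvegicus as the target, read by LC-MS, at a dose of 5 mg/kg by the intravenous route (on this read-out lower numbers stand for slow clearance and higher numbers for fast clearance), compound 1 gives 96.7 mL/min/kg. Compound 2 `C=CC(=O)N1CC[C@H](N2C(=O)N(c3ccccc3)Cc3cnc(Nc4ccccc4)nc32)C1` keeps the shared core but carries no substituent on the aromatic ring that in compound 1 bears the 4-methylpiperazin-1-yl group; in this assay compound 2 gives 41.7 mL/min/kg. Among the measured compounds shown here, the single measured step, a 2.3-fold lower number from compound 1 to compound 2 (0.37 log units; beyond the scatter), is the only guide to substitution on that ring. On the numbers shown, compound 1 stands highest of the two, with compound 2 the nearest neighbour.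

Compound 3 `C=CC(=O)N1CC[C@H](N2C(=O)N(c3ccccc3)Cc3cnc(Nc4ccc(N5CCN(C)CC5)c(OC)c4)nc32)C1` differs from compound 1 in one place: methoxy in place of hydrogen on an aromatic carbon. For the measured compounds named here, no measured pair adds a methoxy group anywhere in this set, and the step from compound 1 to compound 2 removes a group rather than adding one, so it bears on compound 3 only in showing that a change on this ring can shift this assay modestly. A step in this assay within or only just beyond the scatter is therefore expected, without a firm direction; a slight downward move is taken as the central guess. The expected step is a 1.1-fold lower number from compound 1 to compound 3 (0.06 log units; within the scatter). Compound 3 is estimated at 85 mL/min/kg, within a range from 45 mL/min/kg to 150 mL/min/kg.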

Compound 3, clearance: 91.7 mL/min/kg
Compound 3: middle estimate off by 1.1-fold (0.03 log units), on the low side; the measured number falls inside the stated range.
By their numbers in this assay, from the lowest: compound 2; then compounds 3 and 1 (each within the scatter of the next).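

In this assay, methoxy in place of hydrogen on an aromatic carbon, ortho to the 4-methylpiperazin-1-yl group, gives a 1.1-fold lower number from compound 1 to compound 3 (0.02 log units; within the scatter), so the read-out does not separate compound 1 from compound 3. Among the compounds shown here, this is the first view of an addition to this ring: at this place, a methoxy group of 2 heavy atoms leaves clearance unresolved from that of compound 1, and the step that removes the 4-methylpiperazin-1-yl group remains the only one here beyond the scatter. Nothing at hand accounts for the absence of a readable shift at this position.

From the compounds shown here alone, whether the flat result holds only for methoxy or extends to other groups at this place, such as a chlorine atom, ethoxy or a hydroxyl group, remains open. Also open is whether methoxy would read the same on a ring without the 4-methylpiperazin-1-yl group, and whether morpholine in place of that group would give a clearance nearer the high or the low end of the numbers shown.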